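The source may report more compounds than this note shows. Statements on the series, on what has been measured and on what is new or still open speak of the compounds shown alone.

Compound 1, `CCOC(=O)/C=C/c1ccncc1-c1ccc2cc[nH]c2c1`, is the starting point of this small set. In an assay on a protein complex for inhibition of CDK8/Cyclin C (Homo sapiens), with a stated time of 1 h (a lower number here means a stronger inhibitor, a higher number a weaker inhibitor), compound 1 gives 12.1 nM. Compound 2, `O=C(/C=C/c1ccncc1-c1ccc2cc[nH]c2c1)N1CCOCC1`, keeps the same core and carries a single change: morpholin-4-yl in place of ethoxy on a carbonyl carbon. In this assay compound 2 gives 43.9 nM, and the step of a 3.6-fold higher number from compound 1 to compound 2 (0.56 log units; beyond the scatter) shows that this exchange weakened inhibition by a margin beyond the usual scatter of the measurement.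

Compound 3, `CCOC(=O)/C=C/c1ccncc1-c1ccc2c(ccn2C)c1`, is built on a different core from compound 1; the difference between the two cores is not broken down here. In this assay compound 3 gives 144 nM, the highest number among the three measured compounds.

Compound 4, `Cn1ccc2cc(-c3cnccc3/C=C/C(=O)N3CCOCC3)ccc21`, has not yet been measured. It stands to compound 3 exactly as compound 2 stands to compound 1: morpholin-4-yl in place of ethoxy on a carbonyl carbon. The surroundings of the exchange read the same in both pairs, so this is the same change made once already, now on the second core.

Because the measured step of a 3.6-fold higher number from compound 1 to compound 2 (0.56 log units; beyond the scatter) weakened inhibition, the same change is expected to weaken compound 4 by a comparable margin, a 3.5-fold higher number from compound 3 to compound 4 (0.54 log units; beyond the scatter). This rests on a single precedent, and the second core could respond differently, so the range is kept wide. Compound 4 is therefore estimated to give roughly 500 nM in this assay, most likely between 200 nM and 1300 nM.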

Compound 4, half-maximal inhibitory concentration: 247 nM
The estimate for compound 4 lay 2.0-fold (0.31 log units) above the measured number, and the stated range covers the measured number.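

On the second core, the exchange of ethoxy for morpholin-4-yl in this assay gives a 1.7-fold higher number from compound 3 to compound 4 (0.23 log units; within the scatter), so this pair on its own shows no clear loss of inhibition. Set beside the earlier step, the change does not read differently on the two cores, and the gap between the two steps is no larger than repeated measurements could produce: the same change on two cores in this assay, a 3.6-fold higher number (0.56 log units; beyond the scatter) from compound 1 to compound 2 and a 1.7-fold higher number (0.23 log units; within the scatter) from compound 3 to compound 4, 2.1-fold (0.33 log units) apart, within the scatter of two such steps. Within the data shown here, this does not prove that the change has exactly the same effect on both cores, for only one of the two steps stands clear of the scatter, and two pairs are too few to set a rule for the whole series.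

The compounds shown leave open whether the result holds for other groups on the carbonyl carbon, such as a free carboxylic acid, a simple dimethylamino amide, a piperidin-1-yl amide with no ring oxygen, or an ester with a longer chain than ethoxy. They also leave open how the same exchange would behave on any core beyond these two, and a further matched pair on a third core would be needed to test this.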